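Removing the Ethyl Group from Compound 1

This account rests on a few compounds, and the source may have more. Where it says the series, first, only, none or still open, it means among the compounds named here.

Of the compounds shown here, three built on one shared core have been measured in a functional assay on A549 cells (Homo sapiens) for inhibition; a lower number here means a stronger inhibitor, a higher number a weaker inhibitor. Compound 1 `CCc1ccc(N2C(=O)C=CC2OCC(F)(F)F)cc1` gives 8090 nM, the highest of the three numbers. Compound 2 `O=C1C=CC(OC(C(F)(F)F)C(F)(F)F)N1c1ccc(Cl)cc1` gives 4300 nM in this assay, a number within the scatter of that of compound 1, so the two cannot be placed in order. Compound 3 `O=C1C=CC(OCC(F)(F)F)N1c1cc(Cl)cc(Cl)c1` gives 1630 nM in this assay, and its number lies beyond the scatter below that of compound 1.

The unmeasured compound 4 `O=C1C=CC(OCC(F)(F)F)N1c1ccccc1` differs from compound 1 in a single place: hydrogen in place of ethyl on an aromatic carbon. For the measured compounds named here, no two of the measured compounds differ from each other in only one place, and the data therefore hold no measured step of this kind to set against the change. The step from compound 1 to compound 4 is estimated at a 1.4-fold higher number from compound 1 to compound 4 (0.13 log units; within the scatter), toward a higher number, and it may well stay within the scatter. Compound 4 is accordingly expected to give about 11000 nM in this assay, with a range from 4500 nM to 27000 nM.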

Compound 4, half-maximal inhibitory concentration: 23400 nM
The estimate for compound 4 lay 2.1-fold (0.33 log units) below the measured number; the measured number falls inside the stated range.
By their numbers in this assay, from the lowest: compound 3; then compounds 2 and 1 (each within the scatter of the next); then compound 4.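

For the compounds shown here, exchanging ethyl for hydrogen on this aromatic carbon gives a 2.9-fold higher number from compound 1 to compound 4 (0.46 log units; beyond the scatter) in this assay, the only step here that changes a single place, and it lies beyond the scatter. The position is therefore not indifferent to this change: of this pair, compound 1, which carries the ethyl group, is the stronger inhibitor, although the step is modest. Nothing available explains why the number moves with this change.

Going by these compounds, it remains open whether ethyl itself matters here or whether a methyl group, a propyl chain, a methoxy group or an amine at the same place would serve as well or better. On these data alone, it is also open whether the step would keep its size on a compound that differs elsewhere from compound 1.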